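Carbamoyl for Azidohydroxyethyl on a Cyclic Nucleoside Core

This account rests on a few compounds, and the source may have more. Where it says the series, first, only, none or still open, it means among the compounds named here.

Measured compounds:
Compound 1, `[N-]=[N+]=NCC(O)Cn1c(=O)n(C2OC(CO)[C@@H](O)[C@H]2O)c2nc(N)nc(O)c21`: 91%
Compound 2, `Cn1c(=O)n2c3c1c(=O)nc(N)n3CC1OC2[C@H](O)[C@@H]1O`: 9%
Compound 3, `C=CCn1c(=O)n([C@@H](CO)OC(CO)CO)c2nc(N)nc(O)c21`: 0%

In a functional assay on the whole organism (B cells) with Mus musculus as the target (on this read-out higher numbers stand for larger maximal responses and lower numbers for smaller maximal responses), compound 1 gives 91%, the highest of the three numbers. Its nearest neighbour is compound 2 at 9%, a gap well beyond the scatter, and compound 3 at 0% lies furthest away. Compound 4, `NC(=O)Cn1c(=O)n(C2OC(CO)[C@@H](O)[C@H]2O)c2nc(N)nc(O)c21`, has not yet been measured. It differs from compound 1 in one place: carbamoyl in place of 2-azido-1-hydroxyethyl on a saturated chain carbon bound to an aromatic nitrogen. Within the data shown here, no single-change step between measured compounds is available, so the size of this step is not known from the data. Compound 4 is expected to lose part of the response, with a number 36 percentage points lower from compound 1 to compound 4 (beyond the scatter) as the estimated step. For compound 4 the estimated value is 55%, within the range 15% to 95%.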

Compound 4, largest response reached (reported as maximal response), in percent of the reference or control that the assay uses: 32%
Beside the measured number, compound 4's estimate is 23 percentage points above it; the range from low to high includes it.
By their numbers in this assay, from the lowest: compounds 3 and 2 (each within the scatter of the next); then compound 4; then compound 1.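

Swapping 2-azido-1-hydroxyethyl for carbamoyl on a saturated chain carbon bound to an aromatic nitrogen gives, in this assay, a number 59 percentage points lower from compound 1 to compound 4 (beyond the scatter), the first single-change step at this position. The group here therefore matters to the maximal response, yet the change does not abolish it, as compound 4 still gives 32%. Nothing available explains the drop.

Which part of the group carries the response stays open, as this one change replaces the azide, the hydroxyl and the chain together. An amine in place of the azide, or a longer chain ending in carbamoyl, would begin to separate them.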